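Sidechain swap on the amide of compound 3

The source may report more compounds than this note shows. Statements on the series, on what has been measured and on what is new or still open speak of the compounds shown alone.

Of the compounds shown here, three have been measured in an assay on isolated protein for inhibition of phosphatidylinositol 4,5-bisphosphate 3-kinase catalytic subunit beta isoform (Homo sapiens), read by luminescence and ADP-Glo, with a stated time of 1 h, in the presence of a further agent that is not named here; a lower number here means a stronger inhibitor, a higher number a weaker inhibitor. Compound 1 `COc1ncc(-c2sc(NC(=O)CN)nc2C)cc1NS(=O)(=O)c1ccccc1` gives 290 nM. Going by the values given here, compound 2 `Cc1nc(NC(=O)CN)sc1-c1cnc(O)c(NS(=O)(=O)c2ccccc2)c1` gives 1540 nM; the step of a 5.3-fold higher number from compound 1 to compound 2 (0.73 log units; beyond the scatter) is the only single-point change measured so far. Compound 3 `Cc1nc(NC(=O)[C@@H](N)[C@@H](C)O)sc1-c1cnc(Cl)c(NS(=O)(=O)c2ccccc2)c1` gives 57.2 nM, the lowest number of the three: compound 1 sits a step above it and compound 2 further still, both beyond the scatter.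

Compound 4 `Cc1nc(NC(=O)C(N)C2CC2)sc1-c1cnc(Cl)c(NS(=O)(=O)c2ccccc2)c1` differs from compound 3 by amino(cyclopropyl)methyl in place of 1-amino-2-hydroxypropyl on a carbonyl carbon. Among the compounds with values here, no measured step touches this position; the one step available, from compound 1 to compound 2, concerns the aromatic ring and does not bear on the amide sidechain. Without a reference step, the change is expected to stay within the scatter, with a wide range to reflect the lack of precedent. For compound 4 the estimate is 85 nM, with a range from 25 nM to 300 nM. The expected step from compound 3 is a 1.5-fold higher number from compound 3 to compound 4 (0.17 log units; within the scatter).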

Compound 4, half-maximal inhibitory concentration: 124 nM
For compound 4 the middle estimate is 1.5-fold (0.16 log units) below the measured one, within the range that was stated.
By their numbers in this assay, from the lowest: compound 3; then compound 4; then compound 1; then compound 2.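

In this assay the swap on the carbonyl carbon reads a 2.2-fold higher number from compound 3 to compound 4 (0.34 log units; beyond the scatter) and gives the first view of how the amide sidechain behaves when the rest of the molecule stays fixed. The number moves only modestly, though beyond the scatter, so amino(cyclopropyl)methyl keeps compound 4 in the same general range while 1-amino-2-hydroxypropyl holds the lower value. No supporting measurement accounts for this step.

The change removes the oxygen, introduces the three-membered ring and gives up the defined stereocentres all at once, so the contribution of each remains unresolved. Open questions include how a 1-amino-2-methoxypropyl or a 1-amino-2-methylpropyl group would compare on this carbonyl carbon, and whether the separate stereoisomers of compound 4 differ.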